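Swapping One Aryl Group on a Shared Core

The source may report more compounds than this note shows. Statements on the series, on what has been measured and on what is new or still open speak of the compounds shown alone.

The measured compounds, in an assay on CHO cells for displacement of a labelled ligand from adenosine receptor A1 (Homo sapiens), read by scintillation counting, tested at 10 uM; on this read-out higher numbers stand for more inhibition at the one concentration tested (going by the name of the read-out) and lower numbers for less inhibition:
compound 1, `CC(C)(C)Cc1c(-c2cc(F)ccc2F)sc(N)c1C(=O)c1ccc(Cl)cc1`, gives 3%
compound 2, `CC(C)(C)Cc1c(Br)sc(N)c1C(=O)c1ccc(Cl)c(Cl)c1`, gives 1%
compound 3, `CC(C)(C)Cc1c(-c2ccccc2)sc(N)c1C(=O)c1cccc(C(F)(F)F)c1`, gives 1%

All three numbers are close to zero, and the gaps from compound 1 to compound 2 and from compound 1 to compound 3 both lie within the usual scatter of such measurements. Compound 1 therefore cannot be set apart from the other two: on these numbers, none of the three shows meaningful displacement of the labelled ligand at the single concentration tested.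

Compound 4, `COc1ccc(-c2sc(N)c(C(=O)c3ccc(Cl)cc3)c2CC(C)(C)C)cc1`, is the next compound to be measured in this assay. It differs from compound 1 in one place: 4-methoxyphenyl in place of 2,5-difluorophenyl on an aromatic carbon. Going by the values given here, no pair of measured compounds differing in a single place is available to show what such a swap does, so the expectation rests on the three values above, which are all close to zero regardless of the group in that position.

Because compound 1 gives 3% in this assay, the step from compound 1 to compound 4 is expected to be no change at the digits printed from compound 1 to compound 4 (within the scatter), which is nothing beyond the scatter. Compound 4 is thus estimated to give 3%, with a range from -6% to 13%.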

Compound 4, a percentage reported as inhibition, at one concentration (the size of the read-out at that concentration, not a potency): 1%
For compound 4 the middle estimate is 2 percentage points above the measured one, and the stated range covers the measured number.
By their numbers in this assay, from the lowest: compounds 2, 3, 4 and 1 (each within the scatter of the next).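

Placing 4-methoxyphenyl instead of 2,5-difluorophenyl on the aromatic carbon next to the ring sulfur gives a number 2 percentage points lower from compound 1 to compound 4 (within the scatter) in this assay, the first direct comparison in which only this group differs. The exchange is not a trivial one on paper, since the entering group has 1 hydrogen-bond acceptor and the leaving group has 0, yet the two numbers cannot be told apart, and compound 4 joins the other compounds close to zero at the single concentration tested. Nothing else measured here bears on why this exchange leaves the two numbers indistinguishable.

Going by these compounds alone, this single pair covers only two aryl groups on one shared core, and compounds 2 and 3 differ from compound 1 in more than one place, so they cannot show separately what this position contributes. Open too, from the compounds shown here alone, is whether a carboxylic acid or an aminomethyl group in this place, or a shorter chain in place of the neopentyl group, would lift the number clearly beyond the scatter.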